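From compound 2 to compound 3: a hydroxymethyl shift

A few compounds are considered here, and "the series" means these few. Any claim that something is new, unique, unknown or untested is made for them only; others in the source may bear on it.

Compound 1 `FCc1cn(Cc2ccccc2)nn1`: > 100 ug/mL
Compound 2 `CC(=O)N[C@@H]1[C@@H](OC(C)=O)[C@H](OC(C)=O)[C@@H](COC(C)=O)O[C@H]1n1cc(CO)nn1`: > 100 ug/mL

Both entries come from a functional assay on HeLa cells (Homo sapiens), read by colorimetric assay, with a stated time of 72 h; a higher number here means that more compound is needed for the effect, a lower number that less compound is needed. Compound 1 gives > 100 ug/mL, which is a limit of the assay and not a number. Compound 2 gives > 100 ug/mL, which is likewise a limit and not a number. The measured set therefore amounts to the limit of > 100 ug/mL in this assay, at which 2 of the 2 values shown sit, and compound 2 has no numeric position of its own.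

Compound 3 `CC(=O)N[C@@H]1[C@@H](OC(C)=O)[C@H](OC(C)=O)[C@@H](COC(C)=O)O[C@H]1n1nncc1CO` has the same atoms as compound 2, joined differently. It carries 5-(hydroxymethyl)-1H-1,2,3-triazol-1-yl in place of 4-(hydroxymethyl)-1H-1,2,3-triazol-1-yl on a saturated ring carbon. Among the compounds with values here, no measured step gives a size for this change.

No step beyond the scatter is expected in this assay, and another limit is the most likely report. This expectation rests on compound 2, with its limit of > 100 ug/mL. The expected step is a step that the limit leaves unreadable from compound 2 to compound 3. For compound 3 the estimated value is 130 ug/mL, with an expected range of 70 ug/mL to 260 ug/mL.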

Compound 3, concentration for half-maximal effect: > 100 ug/mL
Compound 3 ended at the assay's limit (the forecaster's own chance of this, stated with the estimate: 85%); the middle value is on the limit's open side.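

No step can be read between compound 2 and compound 3, because both values are limits and not numbers: the limit of > 100 ug/mL in this assay, at which 3 of the 3 values shown sit.

The compounds shown leave open whether 5-(hydroxymethyl)-1H-1,2,3-triazol-1-yl and 4-(hydroxymethyl)-1H-1,2,3-triazol-1-yl differ at all on this core, and which change to the series would give a numeric value.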